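Swapping Dibromophenyl for Dimethoxyphenyl on the Oxazole Carbon

The source may hold more compounds than are shown below. What is called first, only, known or untested is meant among the compounds shown, and "the series" means these compounds.

Three compounds share one core and differ in the aryl group that sits on the five-membered ring. Compound 1 is `Cc1ccccc1-c1nc(CN2CCC(C(=O)NCCCN3CCCC(C(C)C)C3)CC2)c(C)o1`, compound 2 is `CC[C@@H]1C[C@H](CC)CN(CCCNC(=O)C2CCN(Cc3nc(-c4c(F)cccc4F)oc3C)CC2)C1` and compound 3 is `Cc1oc(-c2c(Br)cccc2Br)nc1CN1CCC(C(=O)NCCCN2C[C@H](C)C[C@H](C)C2)CC1`. In an ADME assay on Huh7.5.1 cells (Homo sapiens) for cytotoxicity, read by ATP content, with a stated time of 48 h (a higher number here means that more compound is tolerated, a lower number that less compound is tolerated), compound 1 gives 5820 nM. In this assay compound 2 gives 12600 nM. In this assay compound 3 gives 6500 nM, which places it second highest of the three numbers; compound 1 lies nearest to it and compound 2 furthest, yet both gaps fall within the usual scatter, so the three values cannot be ranked against one another.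

Compound 4 is `COc1cccc(OC)c1-c1nc(CN2CCC(C(=O)NCCCN3C[C@H](C)C[C@H](C)C3)CC2)c(C)o1`. Against compound 3 it differs in one place: 2,6-dimethoxyphenyl in place of 2,6-dibromophenyl on an aromatic carbon. For the measured compounds named here, no pair of measured compounds carries this change, so any expectation rests only on the narrow spread of the three measured values.

Compound 4 is expected to land at 9000 nM in this assay, with a range from 4500 nM to 20000 nM. The expected step of a 1.4-fold higher number from compound 3 to compound 4 (0.14 log units; within the scatter) is a small one toward a higher number, of a size that may not exceed the scatter.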

Compound 4, half-maximal cytotoxic concentration: 77100 nM
For compound 4 the middle estimate is 8.6-fold (0.93 log units) below the measured one; the measured number lies above the stated range.
By their numbers in this assay, from the lowest: compounds 1, 3 and 2 (each within the scatter of the next, the first and the last beyond it); then compound 4.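

In this assay, the aryl group on this aromatic carbon of the five-membered ring proves able to move the number a long way: 2,6-dimethoxyphenyl in place of 2,6-dibromophenyl, with the rest of the structure unchanged, gives a 12-fold higher number from compound 3 to compound 4 (1.07 log units; beyond the scatter) in a single change. For the compounds shown here, compound 1, compound 2 and compound 3 differ from one another in more than one place, so they offered no step that isolated this position, and their values could not show how much this aryl group alone can matter. Nothing available here gives a measured property that would account for this step.

The two compounds of this step leave open whether the higher number follows from the methoxy groups themselves, or whether a phenyl ring carrying hydroxyl groups, amino groups or ethoxy groups in their place would give a similar number. Going by these compounds, it also remains open whether the same exchange of aryl groups would give a step of this size when made on the isopropyl-substituted side chain of compound 1 or the diethyl-substituted side chain of compound 2.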